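The source may report more compounds than this note shows. Statements on the series, on what has been measured and on what is new or still open speak of the compounds shown alone.

Three compounds on the shared core have numbers in a functional assay on MCF7 cells (Homo sapiens) for antiproliferative activity, read by MTT assay, with stated times of 24 h and 72 h; a higher number here means a weaker inhibitor, a lower number a stronger inhibitor. Compound 1 `COc1cc(N2C(=O)[C@@H](Oc3ccccc3)[C@H]2c2cccc3ccccc23)cc(OC)c1OC` gives 53000 nM, compound 2 `COc1cc(N2C(=O)[C@@H](Oc3ccccc3)[C@H]2c2ccc(SC)cc2)cc(OC)c1OC` gives 7700 nM, and compound 3 `COc1ccc([C@@H]2[C@H](Oc3ccccc3)C(=O)N2c2cc(OC)c(OC)c(OC)c2)c(N)c1O` gives 19000 nM, the middle one of the three numbers. Compound 4 `COc1cc(N2C(=O)[C@@H](Oc3ccccc3)[C@H]2c2cccc(N)c2)cc(OC)c1OC` has not yet been measured. The change at issue is a group of 7 heavy atoms (6 carbon, 1 nitrogen; one six-membered aromatic ring of carbon only) in place of a group of 10 heavy atoms (7 carbon, 1 nitrogen, 2 oxygen; one six-membered aromatic ring of carbon only), on a saturated ring carbon, with 3-aminophenyl entering on a saturated ring carbon of the four-membered ring.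

All three measured steps involve a swap at this same carbon, and all are modest: a 6.9-fold lower number from compound 1 to compound 2 (0.84 log units; beyond the scatter), a 2.8-fold lower number from compound 1 to compound 3 (0.45 log units; beyond the scatter) and a 2.5-fold higher number from compound 2 to compound 3 (0.39 log units; beyond the scatter). The last of these bears most directly, since compound 2 and compound 3 each carry one six-membered aromatic ring of carbon only at this carbon, as compound 4 does. Among the compounds with values here, no measured compound shows what 3-aminophenyl itself does, so the direction is not settled by the data. In this assay a step no larger than those modest ones is expected, most likely none beyond the scatter, with a slight lean towards a lower number. The estimated step is a 1.5-fold lower number from compound 3 to compound 4 (0.16 log units; within the scatter). Compound 4 is expected at 13000 nM, with an estimated range of 3500 nM to 45000 nM.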

Compound 4, half-maximal inhibitory concentration: 17000 nM
For compound 4 the middle estimate is 1.3-fold (0.12 log units) below the measured one; low and high end bracket the measured number.
By their numbers in this assay, from the lowest: compound 2; then compounds 4 and 3 (each within the scatter of the next); then compound 1.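

In this assay, the group of compound 3 and 3-aminophenyl are not separated at this saturated ring carbon, despite their different counts of heavy atoms, hydrogen-bond donors and hydrogen-bond acceptors: a 1.1-fold lower number from compound 3 to compound 4 (0.05 log units; within the scatter). The two further comparisons with 3-aminophenyl are modest and point in opposite directions, a 2.2-fold higher number from compound 2 to compound 4 (0.34 log units; beyond the scatter) and a 3.1-fold lower number from compound 1 to compound 4 (0.49 log units; beyond the scatter), so compound 4 sits in the same middle place as compound 3, with 4-(methylsulfanyl)phenyl still giving the lowest number and naphthalen-1-yl the highest. No measurement at hand explains any of these steps.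

Still open, going by these compounds, is whether the level seen with 3-aminophenyl depends on where the amine sits or on the amine itself, which 4-aminophenyl and 3-hydroxyphenyl at the same carbon would test. Also open, on these data alone, is whether 3-(methylsulfanyl)phenyl would match the number of compound 2, and whether a carboxylic acid on the phenyl ring at this carbon would shift the number beyond the modest steps seen so far.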